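The compounds below may be only part of what the source reports. "The series", "measured", "known", "first", "only" and "open" are said of these compounds alone.

Compound 1 `COc1cc(-c2cc(/C=C/C(=O)c3ccc(Cl)c(Cl)c3)[nH]n2)cc(OC)c1OC`: in a functional assay on NCI-H226 cells (Homo sapiens) for inhibition, read by sulforhodamine B assay, with a stated time of 48 h (a lower number here means a stronger inhibitor of growth, a higher number a weaker inhibitor of growth), the result for compound 1 is a limit, > 100000 nM.
Compound 2 `COc1ccc(C(=O)/C=C/c2cc(-c3cc(OC)c(OC)c(OC)c3)n[nH]2)cc1`: in this assay compound 2 gives 4070 nM.

Compound 2 stands alone with an actual number; the other result is only a limit of the assay (the limit of > 100000 nM in this assay, at which 1 of the 2 values shown sits). Going by the values given here, the single measured step, an at least 24-fold lower number from compound 1 to compound 2 (1.39 log units; beyond the scatter), is large and runs toward the lower number when 4-methoxyphenyl replaces 3,4-dichlorophenyl on the carbonyl carbon.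

Compound 3 `COc1cc(-c2cc(/C=C/C(=O)c3ccc(F)c(F)c3)[nH]n2)cc(OC)c1OC` turns back toward a dihalogenated ring: 3,4-difluorophenyl in place of 4-methoxyphenyl on a carbonyl carbon. Among the compounds with values here, the only step that bears on this change is an at least 24-fold lower number from compound 1 to compound 2 (1.39 log units; beyond the scatter), which moves in the opposite direction and beyond the scatter. A rise in number is therefore expected for compound 3, probably not as far as the limit seen for compound 1, since fluorine rather than chlorine enters. Compound 3 is estimated at 30000 nM, with a range from 8000 nM to 120000 nM. This estimate means an expected step of a 7.4-fold higher number from compound 2 to compound 3 (0.87 log units; beyond the scatter).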

Compound 3, concentration for total growth inhibition: 15800 nM
Compound 3: the middle estimate sits 1.9-fold (0.28 log units) above what was measured; low and high end bracket the measured number.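

Compound 3 shows that a dihalogenated phenyl on this carbonyl carbon can still give a real number in this assay, with an at least 6.3-fold lower number from compound 1 to compound 3 (0.80 log units; beyond the scatter) when 3,4-difluorophenyl replaces 3,4-dichlorophenyl. That step has only a lower bound, since the result for compound 1 is a limit of the assay: the limit of > 100000 nM in this assay, at which 1 of the 3 values shown sits. Against 4-methoxyphenyl the difluorinated ring still gives the weaker result, with a 3.9-fold higher number from compound 2 to compound 3 (0.59 log units; beyond the scatter), so the three groups fall in one order at this place: 4-methoxyphenyl gives the lowest number, then 3,4-difluorophenyl, then 3,4-dichlorophenyl.

Going by these compounds, three groups cannot show what drives that order, and it remains open where an unsubstituted phenyl, a phenyl carrying a single fluorine or one carrying an amine would fall. On these data alone, whether the order would hold with the rest of the core changed also remains open.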